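The source may report more compounds than this note shows. Statements on the series, on what has been measured and on what is new or still open speak of the compounds shown alone.

In a functional assay on A549 cells (Homo sapiens) for cytotoxicity, read by MTT assay, with a stated time of 72 h (a higher number here means a weaker inhibitor, a lower number a stronger inhibitor), compound 1 (`Cc1ccc(-c2ccnc(C(=O)Nc3ccc(Oc4ccnc5[nH]ccc45)cc3)c2)cc1`) gives > 10000 nM, which is a limit of the assay and not a number. Compound 2 (`COc1ccc(-c2ccnc(C(=O)Nc3ccc(Oc4ccnc5[nH]ccc45)cc3)c2)cc1`) gives 6970 nM. Compound 3 (`O=C(Nc1ccc(Oc2ccnc3[nH]ccc23)cc1)c1cc(-c2ccc(Cl)cc2)ccn1`) gives 4310 nM. Compound 3 therefore stands level with compound 2 (a 1.6-fold lower number from compound 2 to compound 3 (0.21 log units; within the scatter)), and only its comparison with compound 1 clears the scatter (an at least 2.3-fold lower number from compound 1 to compound 3 (0.36 log units; beyond the scatter)). The remaining comparison (an at least 1.4-fold lower number from compound 1 to compound 2 (0.15 log units; that floor lies within the scatter)) has a floor that does not clear it.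

Compound 4 (`O=C(Nc1ccc(Oc2ccnc3[nH]ccc23)cc1)c1cc(-c2ccccc2)ccn1`) removes the chlorine from compound 3 (hydrogen in place of chloro on an aromatic carbon): hydrogen in place of chloro on an aromatic carbon, so that 4-chlorophenyl becomes phenyl. For the measured compounds named here, no measured step places hydrogen on this carbon, so the support is indirect and rests on the three substituted compounds. The measured steps that bear on the change are those into chloro. A modest move to a higher number is expected because an at least 2.3-fold lower number from compound 1 to compound 3 (0.36 log units; beyond the scatter) is the one clear gain seen on introducing chloro, though the size of that step is only a floor. The step from methoxy, a 1.6-fold lower number from compound 2 to compound 3 (0.21 log units; within the scatter), argues against expecting anything large. The estimated step is a 1.7-fold higher number from compound 3 to compound 4 (0.24 log units; within the scatter), and a reading at the assay limit remains possible. For compound 4 the estimated value is 7500 nM, with an expected range from 3500 nM to 16000 nM.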

Compound 4, half-maximal inhibitory concentration: 2920 nM
Estimate against measurement, compound 4: 2.6-fold (0.41 log units) above; the measured number lies below the stated range.
By their numbers in this assay, from the lowest: compounds 4, 3 and 2 (each within the scatter of the next, the first and the last beyond it). At a limit, above all of these: compound 1.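

In this assay, removing the chlorine costs nothing measurable (a 1.5-fold lower number from compound 3 to compound 4 (0.17 log units; within the scatter)), so the 4-chlorophenyl of compound 3 holds no advantage over the plain phenyl of compound 4, and chloro is not required on this aromatic carbon. Hydrogen on this carbon also clears the scatter against methoxy (a 2.4-fold lower number from compound 2 to compound 4 (0.38 log units; beyond the scatter)) and against methyl (an at least 3.4-fold lower number from compound 1 to compound 4 (0.53 log units; beyond the scatter)), so among the four compounds no substituent at this place improves on hydrogen: chloro stays level with it, while methoxy and methyl go with higher numbers. The step from methyl gives only a floor, as the reading for compound 1 is a limit and not a number: the limit of > 10000 nM in this assay, at which 1 of the 4 values shown sits.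

On these data alone, whether any group on this carbon can take the number clearly below that of compound 4 stays open, and an amine, a carboxylic acid or a longer alkoxy chain here would test this. Also open, as far as these compounds go, is whether the same ranking holds on another carbon of this ring, as every substituent shown sits para to a large group.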